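Pyridin-4-yl on the oxadiazole: expectation for compound 4

The source may hold more compounds than are shown below. What is called first, only, known or untested is meant among the compounds shown, and "the series" means these compounds.

Compound 3 `COc1ccc(OC)c(-c2nc(-c3cnccn3)no2)c1` holds the lowest position among the three measured numbers: in a functional assay on the whole organism (strain Charles Foster albino) for inhibition, with Rattus norvegicus as the target, read by paw edema, with stated times of 30 min and 3 h, at a dose of 50 mg/kg by the oral route (a higher number here means more inhibition at the dose given (going by the name of the read-out), a lower number less inhibition), compound 3 gives 11%. Its nearest neighbour is compound 1 `COc1ccc(OC)c(-c2nc(-c3ccccn3)no2)c1`, which in this assay gives 28%; the furthest is compound 2 `CN(C)c1ccc(C2CC(c3ccccn3)=NN2c2ccccc2)cc1`, built on a different core, which in this assay gives 35%.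

The change under consideration is pyridin-4-yl in place of pyrazin-2-yl on an aromatic carbon, giving compound 4 `COc1ccc(OC)c(-c2nc(-c3ccncc3)no2)c1`. Among the measured compounds shown here, one measured step bears on it, though only in part: a number 17 percentage points lower from compound 1 to compound 3 (beyond the scatter). That step exchanged pyridin-2-yl for pyrazin-2-yl at the same position; the present change removes pyrazin-2-yl again but brings in pyridin-4-yl rather than pyridin-2-yl, so the earlier step is not simply reversed. A rise of moderate size is nevertheless expected, with the number for compound 4 likely settling between that of compound 3 and that of compound 1.

In this assay compound 4 is therefore expected at 20%, within 5% to 38%, corresponding to an expected step of a number 9 percentage points higher from compound 3 to compound 4 (within the scatter).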

Compound 4, a percentage reported as inhibition, in the whole organism at one dose (the size of the read-out at that dose, not a potency): 35%
Compound 4: middle estimate off by 15 percentage points, on the low side, and the stated range covers the measured number.
By their numbers in this assay, from the lowest: compound 3; then compounds 1, 2 and 4 (each within the scatter of the next).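

In this assay, replacing pyrazin-2-yl with pyridin-4-yl gives a number 24 percentage points higher from compound 3 to compound 4 (beyond the scatter) and so offsets the earlier fall, a number 17 percentage points lower from compound 1 to compound 3 (beyond the scatter), seen when pyrazin-2-yl entered at this position. The exchange of pyridin-2-yl for pyridin-4-yl gives a number 7 percentage points higher from compound 1 to compound 4 (within the scatter), so these two groups are not separated here, and moving the ring nitrogen within the pyridine ring has no readable consequence. Among the compounds sharing this core, pyrazin-2-yl is therefore the one group that stands apart.

As far as these compounds go, whether pyridin-3-yl or plain phenyl at this position would keep the number at the level of the two pyridinyl compounds stays open, as does the outcome of adding an amine to the pyridine ring. With a single dose, these numbers give the size of the inhibition and not a potency, and nothing available explains why pyrazin-2-yl differs from the two pyridinyl groups.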